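The source may report more compounds than this note shows. Statements on the series, on what has been measured and on what is new or still open speak of the compounds shown alone.

Compound 1, `CC(=O)N1c2ccccc2CCC1C(=O)Nc1ccccc1O`, gives 54500 nM in a functional assay on HCT-15 cells (Homo sapiens) for cytotoxicity, read by sulforhodamine B assay, with a stated time of 72 h; on this read-out higher numbers stand for weaker inhibition of growth and lower numbers for stronger inhibition of growth. Compound 2, `CC(=O)N1c2ccccc2CCC1C(=O)Nc1cc(C(F)(F)F)cc(C(F)(F)F)c1`, reaches only a limit in this assay, > 70000 nM. Compound 3, `O=C(Nc1ccccc1C(F)(F)F)C1CCc2ccccc2N1`, gives 40400 nM in this assay.

Among these three, compound 2 is the one for which no number is known: its result is the limit of > 70000 nM in this assay, at which 1 of the 3 values shown sits, so where it stands relative to compound 1 and compound 3 cannot be said beyond that. The unmeasured compound 4, `CCCCCCCCC(=O)N1c2ccccc2CCC1C(=O)Nc1cc(C(F)(F)F)cc(C(F)(F)F)c1`, keeps the whole of compound 2 and differs from it in one place: heptyl in place of hydrogen on a saturated chain carbon bound to a carbonyl carbon. Going by the values given here, no pair of measured compounds here differs in one place, so no measured step gives a direct guide to the size of this change. With compound 1 and compound 3, both carrying smaller groups on the same kind of core, sitting within a modest distance of each other, and compound 2 known only as a limit, the heptyl addition is expected to move the result by no more than the usual scatter, if at all. Compound 4 is therefore expected near 60000 nM, within a range from 20000 nM to 150000 nM. The step this implies, an at least 1.1-fold lower number from compound 2 to compound 4 (0.06 log units; that floor lies within the scatter), is an estimate and may again end in a limit.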

Compound 4, concentration for 50% growth inhibition: 4970 nM
Compound 4: middle estimate off by 12-fold (1.08 log units), on the high side; measured number outside the range, below it.
By their numbers in this assay, from the lowest: compound 4; then compounds 3 and 1 (each within the scatter of the next). At a limit, above all of these: compound 2.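

The position, a saturated chain carbon bound to a carbonyl carbon, proves far from silent: heptyl in place of hydrogen there gives an at least 14-fold lower number from compound 2 to compound 4 (1.14 log units; beyond the scatter) in this assay. Going by these compounds alone, this is the first step that can be read at all, and it shows that a change confined to the acyl side, read one bond further out as acetyl to octylcarbonyl, is enough on its own to bring a clear number out of a compound that gave none. The size of the step is only a floor, since compound 2 stands at a limit and not at a number: the limit of > 70000 nM in this assay, at which 1 of the 4 values shown sits.

A single step at a single place leaves open whether the lower number grows steadily with chain length or belongs to heptyl in particular, and an ethyl or butyl group, a longer chain such as undecyl, or a chain ending in an amine or a carboxylic acid would help to settle that. From the compounds shown here alone, it also remains open whether the same change on compound 1, with its different group on the amide nitrogen, would give a step of similar size.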